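The source may hold more compounds than are shown below. What is called first, only, known or untested is meant among the compounds shown, and "the series" means these compounds.

Measured in a physicochemical assay for solubility, in phosphate buffer, at pH 7.4; a higher number here means a more soluble compound, a lower number a less soluble compound:
- compound 1 `OCCC1CCN(c2nccnc2OC2CN(c3ccc4ccccc4n3)C2)CC1` gives 84000 nM
- compound 2 `OC1CN(c2nccnc2OC2CN(c3ccc4ccccc4n3)C2)C1` gives 41000 nM
- compound 3 `CN(C)C1CCN(c2nccnc2OC2CN(c3ccc4ccccc4n3)C2)CC1` gives 500000 nM

Compound 3 has the highest number of the three, and both other compounds lie lower by more than the scatter. Compound 4 `OCc1cccc(-c2nccnc2OC2CN(c3ccc4ccccc4n3)C2)c1` keeps the shared core but has 3-(hydroxymethyl)phenyl in place of 4-(dimethylamino)piperidin-1-yl on an aromatic carbon. Within the data shown here, no measured compound carries a six-membered aromatic ring of carbon only at that place, so no step matches this change directly.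

Two steps offer an indirect guide. Compounds 1 and 2 both carry a hydroxy group in the varied part, and the measured steps to compound 3 are modest in one case, a 6.0-fold higher number from compound 1 to compound 3 (0.77 log units; beyond the scatter), and large in the other, a 12-fold higher number from compound 2 to compound 3 (1.09 log units; beyond the scatter). Among the measured compounds shown here, these two compounds are the only basis for this comparison, and neither goes against it. Compound 4 also carries a hydroxy group and lacks the dimethylamino group, so it is expected to fall below compound 3, probably near or somewhat under the two hydroxy compounds. The expected change in this assay is downward and large, with a 25-fold lower number from compound 3 to compound 4 (1.40 log units; beyond the scatter) as the estimate. The estimated value for compound 4 is 20000 nM with an expected range (4000 nM to 80000 nM).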

Compound 4, solubility: 29000 nM
The estimate for compound 4 lay 1.5-fold (0.16 log units) below the measured number; the measured number falls inside the stated range.
By their numbers in this assay, from the lowest: compounds 4 and 2 (each within the scatter of the next); then compound 1; then compound 3.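

In this assay, among these compounds, the 3-(hydroxymethyl)phenyl group on this aromatic carbon gives a 17-fold lower number from compound 3 to compound 4 (1.24 log units; beyond the scatter) and is the first six-membered aromatic ring of carbon only seen at this place, so the series now extends beyond saturated nitrogen-linked rings. Compared with the two other hydroxy compounds, the result differs by partner: a 1.4-fold lower number from compound 2 to compound 4 (0.15 log units; within the scatter) stays within the scatter, whereas a 2.9-fold lower number from compound 1 to compound 4 (0.46 log units; beyond the scatter) lies beyond it, so compound 4 cannot be told apart from the 3-hydroxyazetidin-1-yl compound but does separate from the 4-(2-hydroxyethyl)piperidin-1-yl compound. All three hydroxy compounds now stand below the single dimethylamino compound, and none of the four goes against this, although nothing shown gives a reason for these differences.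

Compound 4 changes the ring and the substituent together, so the compounds shown cannot separate what the phenyl ring contributes from what the hydroxymethyl group contributes. On these data alone, it remains open whether a dimethylaminomethyl group or a carboxylic acid in place of the hydroxymethyl on the same phenyl ring would stay near compound 4 or move towards compound 3.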